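The compounds below may be only part of what the source reports. "The series", "measured", "known", "first", "only" and "open" are said of these compounds alone.

Measured compounds:
Compound 1, `S=C(Nc1ccc(Cl)c(Cl)c1)Nc1nc[nH]n1`: in an ADME assay on MT4 cells (Homo sapiens) for cytotoxicity, read by MTT assay, with a stated time of 96 h (on this read-out lower numbers stand for higher toxicity in this test and higher numbers for lower toxicity in this test), compound 1 gives 47000 nM.
Compound 2, `S=C(Nc1ccc(Br)cc1)Nc1nc[nH]n1`: in this assay compound 2 gives > 100000 nM, which is a limit of the assay and not a number.

Compound 2 therefore stands at the top edge of what this assay reports; where it lies beyond that edge is not known. Of compound 1 only its number is shown, so these two values tell nothing more than that one is a number and the other a limit, as stated in the limit of > 100000 nM in this assay, at which 1 of the 2 values shown sits.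

Compound 3, `S=C(Nc1ccc(Cl)cc1)Nc1nc[nH]n1`, differs from compound 2 in one place: chloro in place of bromo on an aromatic carbon. Within the data shown here, with no measured step to guide it, the expected step of a number no higher from compound 2 to compound 3 (the limit leaves the size open) in this assay is none beyond the usual scatter. The estimated value for compound 3 is 100000 nM, expected to fall between 40000 nM and 250000 nM.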

Compound 3, half-maximal cytotoxic concentration: 47000 nM
The estimate for compound 3 lay 2.1-fold (0.33 log units) above the measured number; the measured number falls inside the stated range.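

Chloro in place of bromo at this place on the aromatic ring gives an at least 2.1-fold lower number from compound 2 to compound 3 (0.32 log units; beyond the scatter) in this assay, so this one-atom change does move the read-out, towards higher toxicity in this test. Compound 2 holds a limit and not a number, so only the lower end of that step is known: the limit of > 100000 nM in this assay, at which 1 of the 3 values shown sits. Hydrogen in place of chloro on an aromatic carbon, by contrast, gives no change at the digits printed from compound 1 to compound 3 (within the scatter), so the second chloro of compound 1 brings no visible difference in this test.

The compounds shown leave open how far this read-out would shift with a different group at the same place, such as fluoro, methyl, methoxy or an amine. With only chloro and bromo there, they also cannot say whether any trend runs through such groups.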